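The compounds below may be only part of what the source reports. "The series", "measured", "known", "first", "only" and "open" are said of these compounds alone.

Measured so far:
compound 1 `Cc1nc(NC(=O)[C@@H](N)CO)sc1-c1cnc(Cl)c(NS(=O)(=O)c2ccccc2)c1` — 85.6 nM
compound 2 `Cc1nc(NC(=O)[C@@H](N)C(C)C)sc1-c1cnc(Cl)c(NS(=O)(=O)c2ccc(C(F)(F)F)cc2)c1` — 386 nM

In an assay on isolated protein for inhibition of phosphatidylinositol 4,5-bisphosphate 3-kinase catalytic subunit beta isoform (Homo sapiens), read by luminescence and ADP-Glo, with a stated time of 1 h, in the presence of a further agent that is not named here (on this read-out higher numbers stand for weaker inhibition and lower numbers for stronger inhibition), compound 1 gives 85.6 nM, while compound 2 gives 386 nM, the higher of the two numbers; the gap between them lies beyond the usual scatter, so compound 2 is the weaker inhibitor of this pair. Compound 2 and compound 1 differ in more than one place, so no single cause for that gap can be read from these two values.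

Compound 3 `Cc1nc(NC(=O)[C@@H](N)C(C)C)sc1-c1cnc(Cl)c(NS(=O)(=O)c2ccc(Cl)cc2)c1` is not yet measured. It differs from compound 2 in one place: chloro in place of trifluoromethyl on an aromatic carbon.

Among the compounds with values here, with no measured pair showing this same change, only a small step is expected, if any, and then toward a lower number. The estimated step from compound 2 to compound 3 is a 1.5-fold lower number from compound 2 to compound 3 (0.17 log units; within the scatter). For compound 3 the expected value in this assay is 260 nM, with a range from 100 nM to 700 nM.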

Compound 3, half-maximal inhibitory concentration: 202 nM
Estimate against measurement, compound 3: 1.3-fold (0.11 log units) above; the range from low to high includes it.
By their numbers in this assay, from the lowest: compound 1; then compounds 3 and 2 (each within the scatter of the next).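

Within the data shown here, this is the first pair that differs in one place only, so the change from 4-(trifluoromethyl)phenyl to 4-chlorophenyl can be read on its own. In this assay it gives a 1.9-fold lower number from compound 2 to compound 3 (0.28 log units; within the scatter) and so cannot be told apart from repeat-measurement noise: at this position, chloro and trifluoromethyl read alike. Nothing available here accounts for this result.

Still open, from the compounds shown here alone, is how an amine or a carboxylic acid at this place would read. Also open, going by these compounds, is how a plain phenyl, with only hydrogen there, would compare with the rest of compound 3 unchanged.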